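The source may hold more compounds than are shown below. What is called first, only, known or untested is meant among the compounds shown, and "the series" means these compounds.

Compound 1, `COc1cc(NC(C)CCCN2C(=O)[C@@H](C)N(C(=O)CN)C2(C)C)c2ncccc2c1`, and compound 2, `COc1cc(NC(C)CCCN2C(=O)CN(C(=O)[C@H](N)CCSC)C2(C)C)c2ncccc2c1`, share one core and differ in the group attached through the carbonyl at the ring nitrogen. In a physicochemical assay for solubility (a lower number here means a less soluble compound, a higher number a more soluble compound), compound 1 gives 110000 ug/mL, while compound 2 gives 11700 ug/mL. Compound 2 therefore stands at the lower of the two numbers, and the gap to compound 1 is beyond the usual scatter of such measurements.

Compound 3, `COc1cc(NC(C)CCCN2C(=O)CN(C(=O)CN)C2(C)C)c2ncccc2c1`, has not yet been measured in this assay. It comes from compound 2 by one change: hydrogen in place of 2-(methylsulfanyl)ethyl on a saturated chain carbon bound to an amine nitrogen and a carbonyl carbon. Among the compounds with values here, the side chain that leaves is the only part that sets compound 2 apart from the simpler aminomethyl carbonyl carried by compound 1, so compound 3 is expected to move back toward the higher number.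

Within the data shown here, no measured step between neighbours is available, so the size of the move rests on the two values above. The expected step from compound 2 to compound 3, a 7.7-fold higher number from compound 2 to compound 3 (0.89 log units; beyond the scatter), is an increase clearly beyond the scatter. Compound 3 is estimated to give about 90000 ug/mL in this assay, within a range from 35000 ug/mL to 200000 ug/mL.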

Compound 3, solubility: 150000 ug/mL
Estimate against measurement, compound 3: 1.7-fold (0.22 log units) below, within the range that was stated.
By their numbers in this assay, from the lowest: compound 2; then compounds 1 and 3 (each within the scatter of the next).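

In this assay the swap of 2-(methylsulfanyl)ethyl for hydrogen, on a saturated chain carbon bound to an amine nitrogen and a carbonyl carbon, gives a 13-fold higher number from compound 2 to compound 3 (1.11 log units; beyond the scatter) and counts as a large step. Compounds 1 and 2 differ in more than one place, so their gap could not be assigned to either place, whereas this pair differs only in the side chain and isolates that single change. Hydrogen in place of methyl on a saturated ring carbon gives a 1.4-fold higher number from compound 1 to compound 3 (0.13 log units; within the scatter) and stays within the scatter, so in this pair the methyl change leaves no readable difference, and the large step belongs to the side chain alone.

The compounds shown leave open whether the size of that step goes with the length of the chain or with its sulfur atom, and a plain propyl chain or a 2-hydroxyethyl group on the same saturated chain carbon would help to separate the two. Nothing available here gives a measured reason for the size of the step.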